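Working notes on cytotoxicity in a small series

This account rests on a few compounds, and the source may have more. Where it says the series, first, only, none or still open, it means among the compounds named here.

Measured in an ADME assay on HepG2 cells (Homo sapiens) for cytotoxicity, read by luminescence, CellTiter-Glo and ATP content, with a stated time of 72 h; on this read-out higher numbers stand for an effect only at larger amounts of compound and lower numbers for an effect already at smaller amounts:
compound 1 `CC(C)Cc1ccc2c(NCCCNCc3ccco3)ccnc2c1` gives 16000 nM
compound 2 `c1ccc(-c2ccc3c(NCCCNCc4ccco4)ccnc3c2)cc1` gives 5920 nM
compound 3 `COc1cccc(CNCCCNc2ccnc3cc(CC(C)C)ccc23)c1O` gives 2920 nM

Two single changes are covered. phenyl in place of isobutyl on an aromatic carbon brings a 2.7-fold lower number from compound 1 to compound 2 (0.43 log units; beyond the scatter). Compound 1 and compound 3 differ by 2-hydroxy-3-methoxyphenyl in place of furan-2-yl on a saturated chain carbon bound to an amine nitrogen, which brings a 5.5-fold lower number from compound 1 to compound 3 (0.74 log units; beyond the scatter) and leaves compound 3 with the lowest of the three numbers, beyond the scatter from both others.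

Compound 4 `COc1cccc(CNCCCNc2ccnc3cc(-c4ccccc4)ccc23)c1O` is not yet measured in this assay. It differs from compound 3 by phenyl in place of isobutyl on an aromatic carbon, the same change, at the same place, as between compound 1 and compound 2; the two cores differ as stated for compound 1 and compound 3. For compound 4 a step of a 2.1-fold lower number from compound 3 to compound 4 (0.32 log units; beyond the scatter) in this assay is expected, close to but somewhat smaller than the earlier one, because a 2.7-fold lower number from compound 1 to compound 2 (0.43 log units; beyond the scatter) was seen on a core that starts from a higher number. The estimate for compound 4 is 1400 nM, between 700 nM and 3000 nM.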

Compound 4, half-maximal effective concentration: 3210 nM
Estimate against measurement, compound 4: 2.3-fold (0.36 log units) below, outside the stated range (above it).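

In this assay phenyl in place of isobutyl on an aromatic carbon does not carry over from one core to the other: the same change on two cores in this assay, a 2.7-fold lower number (0.43 log units; beyond the scatter) from compound 1 to compound 2 and a 1.1-fold higher number (0.04 log units; within the scatter) from compound 3 to compound 4, 3.0-fold (0.47 log units) apart, beyond the scatter of two such steps. The exchange of furan-2-yl for 2-hydroxy-3-methoxyphenyl does not carry over either: the same change on two cores in this assay, a 5.5-fold lower number (0.74 log units; beyond the scatter) from compound 1 to compound 3 and a 1.8-fold lower number (0.27 log units; within the scatter) from compound 2 to compound 4, 3.0-fold (0.47 log units) apart, beyond the scatter of two such steps. On the new core the steps are a 1.1-fold higher number from compound 3 to compound 4 (0.04 log units; within the scatter) and a 1.8-fold lower number from compound 2 to compound 4 (0.27 log units; within the scatter), both within the scatter, so the two changes do not add independently in these compounds, but a single set of four compounds does not show why or whether this holds on any other core.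

Open, going by these compounds, is how a trifluoromethyl or cyclohexyl group on the same aromatic carbon would behave. Also open, on these data alone, is whether a longer chain keeps this pattern.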